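Swapping 2-methoxyethoxy for ethylsulfonyl on the shared core

A few compounds are considered here, and "the series" means these few. Any claim that something is new, unique, unknown or untested is made for them only; others in the source may bear on it.

Measured so far in a physicochemical assay for lipophilicity, at pH 7.4; a higher number here means a more lipophilic compound, a lower number a more polar compound:
- compound 1 `COc1cc2c(cc1OC)[C@H](C)C(=O)N(C)C=C2` gives 3.4
- compound 2 `COc1ccc2c(c1)C=CN(C)C(=O)[C@@H]2C` gives 4.3
- compound 3 `COCCOc1ccc2c(c1)C=CN(C)C(=O)[C@@H]2C` gives 4

Compound 3 (4) matches compound 2 within the scatter and lies clearly above compound 1. On these data alone, compound 4 `CCS(=O)(=O)c1ccc2c(c1)C=CN(C)C(=O)[C@@H]2C` differs from compound 3 by having ethylsulfonyl in place of 2-methoxyethoxy on an aromatic carbon and its value is still unknown. Going by the values given here, the one measured step at this carbon is a number 0.30 log units lower from compound 2 to compound 3 (within the scatter) and it stays inside the scatter. Among the compounds with values here, that step only adds to a chain joined through oxygen, and no measured compound carries ethylsulfonyl, so it offers limited guidance here. Compound 1 (3.4) does show that a change in ring substitution on this core can go with a clearly lower number. The expected change in this assay is therefore downward and beyond the scatter, an estimated a number 0.60 log units lower from compound 3 to compound 4 (beyond the scatter) with real uncertainty. For compound 4 the expected value is 3.4 within an estimated range from 2.9 to 3.9 in this measurement.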

Compound 4, distribution coefficient: 3.1
Compound 4: the middle estimate sits 0.30 log units above what was measured, and the stated range covers the measured number.
By their numbers in this assay, from the lowest: compounds 4 and 1 (each within the scatter of the next); then compounds 3 and 2 (each within the scatter of the next).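

In this assay, this aromatic carbon had so far shown only a number 0.30 log units lower from compound 2 to compound 3 (within the scatter), a change that stayed inside the scatter. Ethylsulfonyl gives the first clear movement here, with a number 0.90 log units lower from compound 3 to compound 4 (beyond the scatter), and the step from the smaller methoxy group is larger still, at a number 1.20 log units lower from compound 2 to compound 4 (beyond the scatter). So the number at this carbon depends on more than the size of the group, as 2-methoxyethoxy and ethylsulfonyl match in heavy atoms and hydrogen-bond acceptors, yet no measurement shown here explains the fall.

The compounds shown leave open how the shorter methylsulfonyl group or an ethylthio group would compare at this carbon. They also leave open whether an amine or a carboxylic acid here would give a number in the same range.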